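A few compounds are considered here, and "the series" means these few. Any claim that something is new, unique, unknown or untested is made for them only; others in the source may bear on it.

Measured in an ADME assay on Vero cells (Chlorocebus sabaeus) for cytotoxicity, read by neutral red uptake, with a stated time of 48 h; on this read-out lower numbers stand for stronger inhibition and higher numbers for weaker inhibition:
Compound 1 `CCCc1cn(Cc2ccccc2O)nn1` gives > 20000 nM
Compound 2 `CCCCCc1cn(Cc2ccccc2O)nn1` gives > 20000 nM
Compound 3 `CC(C)=CCC/C(C)=C/Cn1cc(COc2ccccc2O)nn1` gives > 20000 nM

Each entry is a limit of the assay and not a number. Compound 3 therefore has only the limit > 20000 nM to stand on. The series as a whole sits at the limit of > 20000 nM in this assay, at which 3 of the 3 values shown sit, and shows no readable value.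

Compound 4 `CC(C)=CCC/C(C)=C\Cn1cc(COc2ccccc2O)nn1` is the next case: the two compounds have the same atoms and bonds and differ only in configuration as drawn: 1 of 1 stereo elements differ; a double bond is drawn E in compound 3 and Z in compound 4. Among the compounds with values here, the only measured step, a step that the two limits leave unreadable from compound 1 to compound 2, gives no size and concerns a different change. Within the data shown here, no measured step tests a double bond drawn E against one drawn Z. No shift in either direction beyond the scatter is expected in this assay. The expected step is a step that the limit leaves unreadable from compound 3 to compound 4 as an estimate. Compound 4 is estimated at 25000 nM, with an expected range of 12000 nM to 50000 nM.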

Compound 4, half-maximal inhibitory concentration: > 20000 nM
Compound 4: a limit, no number (the forecaster's own chance of this, stated with the estimate: 85%); the middle value lies beyond the limit too.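

No step can be read from compound 3 to compound 4 in this assay, since both stand only at a limit: the limit of > 20000 nM in this assay, at which 4 of the 4 values shown sit.

The compounds shown leave open whether a double bond drawn E and one drawn Z would differ in this assay if a number could be read.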